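The compounds below may be only part of what the source reports. "The series", "measured", "known", "first", "only" and "open" are said of these compounds alone.

Compound 2 `Oc1ccc(-c2cc(-c3ccsc3)cc(-c3cccc(O)c3)n2)cc1` holds the lower of the two numbers recorded so far in a functional assay on T47D cells (Homo sapiens) for cytotoxicity, read by CCK-8 assay; on this read-out higher numbers stand for weaker inhibition and lower numbers for stronger inhibition. In this assay compound 2 gives 760 nM. Within the data shown here, its only neighbour is compound 1 `Oc1cccc(-c2cc(-c3ccsc3)cc(-c3cccc(O)c3)n2)c1`, which in this assay gives 1510 nM; the single step between them, a 2.0-fold lower number from compound 1 to compound 2 (0.30 log units; within the scatter), concerns where the hydroxyl sits on one phenyl ring and stays within the scatter, so the two compounds cannot be told apart on these numbers. Compound 3 `Oc1ccc(-c2cc(-c3ccccn3)cc(-c3cccc(O)c3)n2)cc1` has not yet been measured. It differs from compound 2 by pyridin-2-yl in place of thiophen-3-yl on an aromatic carbon. Among the measured compounds shown here, no measured step touches this exchange of the five-membered ring for a six-membered one; the step from compound 1 to compound 2 speaks only to the hydroxyphenyl groups. With nothing to lean on, the step from compound 2 to compound 3 is expected to be a 1.1-fold higher number from compound 2 to compound 3 (0.02 log units; within the scatter), with no direction beyond the scatter claimed. Compound 3 is therefore estimated at 800 nM in this assay, within a range from 200 nM to 3200 nM.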

Compound 3, half-maximal inhibitory concentration: 980 nM
Compound 3: middle estimate off by 1.2-fold (0.09 log units), on the low side; low and high end bracket the measured number.
By their numbers in this assay, from the lowest: compounds 2, 3 and 1 (each within the scatter of the next).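

Exchanging thiophen-3-yl for pyridin-2-yl at the position opposite the ring nitrogen gives, in this assay, a 1.3-fold higher number from compound 2 to compound 3 (0.11 log units; within the scatter), so compound 2 and compound 3 cannot be told apart on these numbers. Among these compounds, this is the first measured exchange at this position, as the earlier step concerned only where the hydroxyl sits on one phenyl ring, and it shows that this five-membered ring and this six-membered ring read alike here within the scatter. No measurement on hand accounts for this result.

As far as these compounds go, it remains open whether an amine, a carboxylic acid or a longer chain at this position would move the number beyond the scatter. Also open, from the compounds shown here alone, is whether pyridin-2-yl would read the same on the core of compound 1, with its two 3-hydroxyphenyl groups.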